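The source may report more compounds than this note shows. Statements on the series, on what has been measured and on what is new or still open speak of the compounds shown alone.

Of the compounds shown here, three have been measured in an assay on HEK293 cells for antagonist activity at transient receptor potential cation channel subfamily V member 3 (Homo sapiens), read by FLIPR and calcium flux; a higher number here means a weaker inhibitor, a lower number a stronger inhibitor. Compound 1 `C[C@]1(c2ccc(OC(F)(F)F)cc2)C[C@@](O)(c2ccccn2)CO1` gives 2460 nM in this assay, the highest of the three numbers. Compound 2 `C[C@]1(O)C[C@@](c2cc(C(F)(F)F)ccn2)([C@H](O)c2ccccn2)C1` gives 730 nM in this assay, a number beyond the scatter below that of compound 1. Compound 3 `C[C@]1(O)C[C@](c2cccc(OC(F)(F)F)c2)([C@H](O)c2ccccn2)C1` gives 1310 nM in this assay, which sits within the scatter of compound 1, so no order between those two can be read.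

Compound 4 `C[C@]1(c2ccc(OC(F)(F)F)cc2)C[C@](O)(c2ccccn2)CO1` has not yet been measured. It is built from compound 1 by this change: the two compounds have the same atoms and bonds and differ only in configuration as drawn: 1 of 2 stereo elements differ; a stereocentre at a saturated ring carbon is drawn R in compound 1 and S in compound 4. Nothing leaves and nothing enters; the difference is only in how one centre is drawn.

Among the measured compounds shown here, no step of this kind is found among the measured compounds, so there is no measured guide for its size or direction. Changing the drawn configuration at a ring carbon can move a number either way, and sometimes by a lot. The step from compound 1 to compound 4 is therefore expected to be small, a 1.2-fold lower number from compound 1 to compound 4 (0.09 log units; within the scatter), but with wide uncertainty. Compound 4 is estimated to give 2000 nM in this assay, with a range from 400 nM to 10000 nM.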

Compound 4, antagonist equilibrium constant: 420 nM
Compound 4: middle estimate off by 4.8-fold (0.68 log units), on the high side; the measured number falls inside the stated range.
By their numbers in this assay, from the lowest: compounds 4, 2, 3 and 1 (each within the scatter of the next, the first and the last beyond it).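

In this assay, among the compounds shown here, this is the first pair to isolate a single change, and inverting one stereocentre gives a 5.9-fold lower number from compound 1 to compound 4 (0.77 log units; beyond the scatter), a step beyond the scatter. For the compounds shown here, no earlier pair differed in only one place, so the three earlier values could not show that this saturated ring carbon matters on its own. With no atom gained or lost, the step can be assigned to the drawn configuration at that carbon, because nothing else separates the two compounds: the fact that compounds 1 and 4 differ only in the configuration as drawn

On these data alone, this is a single pair on a single core, so it remains open whether S is also favoured over R at a comparable centre in other cores, and what changing the second stereo element would do. As far as these compounds go, it is also open how the number would respond if an amine or a carboxylic acid replaced the trifluoromethoxy group of compound 4.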